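Adding a Methyl to the Phenyl Ring of Compound 1

A few compounds are considered here, and "the series" means these few. Any claim that something is new, unique, unknown or untested is made for them only; others in the source may bear on it.

Of the compounds shown here, three sharing one core have been tested in a functional assay on U-87MG ATCC cells (Homo sapiens) for inhibition, read by MTT assay, with a stated time of 72 h; a lower number here means a stronger inhibitor, a higher number a weaker inhibitor. Compound 1 `COc1cc2c(Oc3ccc(NC(=O)c4nn(-c5ccccc5)c(=O)cc4C)cc3F)ccnc2cc1OCCCN1CCCC1` gives 1100 nM. Compound 2 `COc1cc2c(Oc3ccc(NC(=O)c4nn(-c5ccccc5)c(=O)cc4C)cc3F)ccnc2cc1OCCCN1CCCCC1` gives 1370 nM, and compound 3 `COc1cc2c(Oc3ccc(NC(=O)c4nn(-c5ccccc5)c(=O)cc4C)cc3F)ccnc2cc1OCCCN1CCN(C)CC1` gives 2120 nM. Compound 1 has the lowest of the three numbers, but the steps of a 1.2-fold higher number from compound 1 to compound 2 (0.10 log units; within the scatter) and a 1.9-fold higher number from compound 1 to compound 3 (0.28 log units; within the scatter) both fall within the scatter, as does a 1.5-fold higher number from compound 2 to compound 3 (0.19 log units; within the scatter), so the three cannot be told apart with confidence.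

Compound 4 `COc1cc2c(Oc3ccc(NC(=O)c4nn(-c5ccccc5C)c(=O)cc4C)cc3F)ccnc2cc1OCCCN1CCCC1` differs from compound 1 by methyl in place of hydrogen on an aromatic carbon. Every measured step instead exchanges the pyrrolidin-1-yl, piperidin-1-yl or 4-methylpiperazin-1-yl group on the saturated chain, and even those changes stayed within the scatter. Among the measured compounds shown here, no measured step touches the part of the molecule altered here, so there is no direct guide. The expected step is no change at the digits printed from compound 1 to compound 4 (within the scatter), one that stays within the scatter in this assay. Compound 4 is therefore estimated at 1100 nM, with a range from 450 nM to 2700 nM.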

Compound 4, half-maximal inhibitory concentration: 2960 nM
Estimate against measurement, compound 4: 2.7-fold (0.43 log units) below, and the stated range ends below it.
By their numbers in this assay, from the lowest: compounds 1, 2, 3 and 4 (each within the scatter of the next, the first and the last beyond it).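

In this assay, replacing phenyl with 2-methylphenyl gives a 2.7-fold higher number from compound 1 to compound 4 (0.43 log units; beyond the scatter) and so a weaker inhibitor, a modest step but the only one in this set that lies beyond the scatter. The earlier compounds shown here varied only the group on the saturated chain, and none of those exchanges moved the number beyond the scatter, whereas here one added methyl on the aromatic ring, ortho to a large group, does. Nothing measured here explains why this methyl weakens inhibition.

From the compounds shown here alone, it remains open whether a chlorine or a methoxy group in the same place would give a similar step, or whether a larger group such as ethyl would give a greater one. Also open, going by these compounds, is whether the same methyl would have a comparable effect with the piperidin-1-yl or 4-methylpiperazin-1-yl group on the chain.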